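The compounds below may be only part of what the source reports. "The series", "measured", "known", "first", "only" and "open" are said of these compounds alone.

Compound 1 `CN1CCN(c2nc3ccccc3n2CCOc2ccccc2)CC1` gives 6.9 nM in a functional assay on ileum for inhibition of histamine H1 receptor (Cavia porcellus) (a higher number here means a weaker inhibitor, a lower number a stronger inhibitor), the lower of the two numbers measured here; compound 2 `CCCOCCn1c(N2CCCN(C)CC2)nc2ccccc21` gives 16 nM in this assay, a gap that lies beyond the usual scatter. Compound 3 `CCCCOCCn1c(N2CCN(C)CC2)nc2ccccc21` has not been measured yet. It differs from compound 1 in one place: butyl in place of phenyl on an oxygen on a saturated carbon. Among the compounds with values here, no measured pair isolates this change, so the direction rests on weak ground. The step expected from this exchange is a 1.7-fold higher number from compound 1 to compound 3 (0.24 log units; within the scatter), a modest loss rather than no change. Compound 3 is therefore estimated at 12 nM, with a range from 4 nM to 35 nM.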

Compound 3, half-maximal inhibitory concentration: 38 nM
Compound 3: the middle estimate sits 3.2-fold (0.50 log units) below what was measured, and the stated range ends below it.
By their numbers in this assay, from the lowest: compound 1; then compound 2; then compound 3.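

In this assay, within the data shown here, replacing phenyl with butyl on this oxygen gives a 5.5-fold higher number from compound 1 to compound 3 (0.74 log units; beyond the scatter) as the first measured step at this position. It shows that, in this pair, the open butyl chain does not match the aromatic ring, and that the change is a real loss rather than one lost in the scatter. Nothing at hand accounts for this loss. Going by these compounds, whether a benzyl group or a cyclohexyl ring on the same oxygen would keep the number of compound 1 stays open, as does the effect of a shorter chain such as ethyl.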